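A few compounds are considered here, and "the series" means these few. Any claim that something is new, unique, unknown or untested is made for them only; others in the source may bear on it.

Working notes on the series. Compound 1 `CCOC(=O)CCN1CCN(c2c(F)cc3c(=O)c(C(=O)O)cn(C4CC4)c3c2OC)CC1C` stands at "not determined" (no result reported) in an ADME assay on Vero cells (Chlorocebus sabaeus) for cytotoxicity, read by MTT assay, with a stated time of 72 h; a lower number here means that less compound is tolerated, a higher number that more compound is tolerated. Compound 2 `COc1c(N2CCN(CCC(C)=O)C(C)C2)c(F)cc2c(=O)c(C(=O)O)cn(C3CC3)c12` gives 9.84 ug/mL in this assay, and compound 3 `COc1c(N2CCN(C/C(C)=N/NC(=O)c3ccncc3)C(C)C2)c(F)cc2c(=O)c(C(=O)O)cn(C3CC3)c12` gives 250 ug/mL in this assay. Compound 2 thus stands lowest of the two numbers, its nearest neighbour being compound 3, reached by a 25-fold higher number from compound 2 to compound 3 (1.40 log units; beyond the scatter). Compound 4 `COc1c(N2CCN(CC/C(C)=N/O)C(C)C2)c(F)cc2c(=O)c(C(=O)O)cn(C3CC3)c12` differs from compound 2 by a group of 4 heavy atoms (2 carbon, 1 nitrogen, 1 oxygen; no ring) in place of a group of 3 heavy atoms (2 carbon, 1 oxygen; no ring), on a saturated chain carbon, two bonds along the chain from an amine nitrogen in a ring. Going by the values given here, the one measured step on the same side chain was large, yet the present change is much smaller in atom count and sits elsewhere on the chain, so only a modest rise in the number is expected, around a 2.0-fold higher number from compound 2 to compound 4 (0.31 log units; beyond the scatter). Compound 4 is accordingly expected to give 20 ug/mL in this assay, within a range from 7 ug/mL to 60 ug/mL.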

Compound 4, half-maximal cytotoxic concentration: 44.2 ug/mL
Beside the measured number, compound 4's estimate is 2.2-fold (0.34 log units) below it, within the range that was stated.
By their numbers in this assay, from the lowest: compound 2; then compound 4; then compound 3.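

At the saturated chain carbon, two bonds along the chain from an amine nitrogen in a ring, replacing acetyl with a group that carries no ring still shifts the number in this assay, with a 4.5-fold higher number from compound 2 to compound 4 (0.65 log units; beyond the scatter). That shift does not span the whole range, since the group bearing the six-membered aromatic ring stays well ahead, with a 5.7-fold lower number from compound 3 to compound 4 (0.75 log units; beyond the scatter). Nothing at hand accounts for either step. As far as these compounds go, whether an amine, a carboxylic acid or a longer chain at this carbon would shift the number in the same direction remains open.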